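A few compounds are considered here, and "the series" means these few. Any claim that something is new, unique, unknown or untested is made for them only; others in the source may bear on it.

For the measured compounds named here, compound 2 `N#CCCCCCc1cnc(C(=O)CCCCCCc2ccccc2)o1` gives the lowest of the two numbers measured so far in an assay for inhibition of Fatty-acid amide hydrolase 1 (Rattus norvegicus), using a Dixon plot (on this read-out lower numbers stand for stronger inhibition and higher numbers for weaker inhibition), at 4.8 nM. Going by the values given here, compound 1 `O=C(CCCCCCc1ccccc1)c1ncc(-c2ccc(CCl)cn2)o1` gives 22.4 nM in this assay, and the only measured step, a 4.7-fold lower number from compound 1 to compound 2 (0.67 log units; beyond the scatter), exchanged the whole group on the aromatic carbon of the shared core. Compound 3 `CSCCCCCc1cnc(C(=O)CCCCCCc2ccccc2)o1` has not been measured; it differs from compound 2 by methylsulfanyl in place of cyano on a saturated chain carbon, five bonds along the chain from an aromatic carbon. Among the compounds with values here, no measured step probes the end of this chain, so the step of a 1.3-fold higher number from compound 2 to compound 3 (0.10 log units; within the scatter) is expected to stay within the scatter. For compound 3 the estimate in this assay is 6 nM, within 2 nM to 18 nM.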

Compound 3, inhibition constant: 8.1 nM
For compound 3 the middle estimate is 1.4-fold (0.13 log units) below the measured one; low and high end bracket the measured number.
By their numbers in this assay, from the lowest: compounds 2 and 3 (each within the scatter of the next); then compound 1.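

In this assay the end of this chain accepts methylsulfanyl in place of cyano, with a 1.7-fold higher number from compound 2 to compound 3 (0.23 log units; within the scatter), so the nitrile is not needed here for a number in this range. The advantage over compound 1 also persists with the new end group, with a 2.8-fold lower number from compound 1 to compound 3 (0.44 log units; beyond the scatter), so that advantage does not depend on the nitrile alone. No further data bear on the reason for this result. Still open, from the compounds shown here alone, is whether an amine, a carboxylic acid or a longer chain at this chain end would give a similar number.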